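The source may hold more compounds than are shown below. What is called first, only, known or untested is meant among the compounds shown, and "the series" means these compounds.

Working notes on the series: in a functional assay on Caco-2 cells (Homo sapiens) for antiproliferative activity, with a stated time of 48 h (a lower number here means a stronger inhibitor, a higher number a weaker inhibitor), compound 1 (`COC(=O)c1cccc(-c2ccc(-n3cccc3)nn2)c1`) gives 50000 nM. Compound 2 (`CCN(CC)c1ccc(-c2ccc(C#N)cc2)nn1`) stands at > 25000 nM, which is a limit of the assay and not a number. Compound 3 (`CCN(CC)c1ccc(-c2ccc(C(=O)OC)cc2)nn1`) carries methoxycarbonyl in place of cyano on an aromatic carbon, para to a large group: methoxycarbonyl in place of cyano on an aromatic carbon. Going by the values given here, no measured pair isolates this change. Compound 1 also carries methoxycarbonyl and gives 50000 nM, so no step beyond the scatter is expected in this assay, in either direction. The estimated step is a step that the limit leaves unreadable from compound 2 to compound 3. For compound 3 the estimated value is 35000 nM, with an expected range of 12000 nM to 100000 nM.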

Compound 3, half-maximal inhibitory concentration: 250 nM
Estimate against measurement, compound 3: 140-fold (2.15 log units) above, outside the stated range (below it).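

Going by these compounds alone, at this position, on an aromatic carbon para to a large group, methoxycarbonyl in place of cyano gives an at least 100-fold lower number from compound 2 to compound 3 (2.00 log units; beyond the scatter) in this assay and thus provides the first measured pair that isolates this change. Compound 2 stands at > 25000 nM as a limit of the assay and not a number. The true size of the step therefore stays unknown, and only its minimum can be read: the limit of > 25000 nM in this assay, at which 1 of the 3 values shown sits.

As far as these compounds go, it remains open whether this activity requires the intact methyl ester, since the carboxylic acid, a primary amide or a longer ester at this position would test that.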